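Fluorinated benzyl replacement on a nucleoside scaffold

The compounds below may be only part of what the source reports. "The series", "measured", "known", "first", "only" and "open" are said of these compounds alone.

Measured compounds:
Compound 1, `OC[C@H]1O[C@@H](n2cnc3c(NCc4ccccc4F)ncnc32)[C@H](O)[C@@H]1O`: 3200 nM
Compound 2, `COc1cccc(CNc2ncnc3c2ncn3[C@@H]2O[C@H](CO)[C@@H](O)[C@H]2O)c1`: 4900 nM

Both were tested in a functional assay on HL-60 cells (Homo sapiens) for antiproliferative activity, with a stated time of 72 h; on this read-out higher numbers stand for weaker inhibition and lower numbers for stronger inhibition. For the measured compounds named here, compound 1 gives 3200 nM, and compound 2 gives 4900 nM; the only step between them is a 1.5-fold higher number from compound 1 to compound 2 (0.19 log units; within the scatter), so the two compounds cannot be told apart on this read-out, and compound 2 simply stands as one of two indistinguishable numbers.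

Compound 3, `OC[C@H]1O[C@@H](n2cnc3c(NCc4c(F)ccc(F)c4F)ncnc32)[C@H](O)[C@@H]1O`, has not yet been measured. Its change from compound 2 is 2,3,6-trifluorophenyl in place of 3-methoxyphenyl on a saturated chain carbon bound to a nitrogen on an aromatic ring. Going by the values given here, the one measured step that bears on this position, a 1.5-fold higher number from compound 1 to compound 2 (0.19 log units; within the scatter), shows that swapping the ring on that saturated chain carbon between a 2-fluorophenyl and a 3-methoxyphenyl left the number essentially unchanged. Placing a 2,3,6-trifluorophenyl there is therefore expected to give no step beyond the scatter in this assay, estimated as a 1.4-fold lower number from compound 2 to compound 3 (0.15 log units; within the scatter). For compound 3 the expected value is 3500 nM, with a range from 1200 nM to 10000 nM.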

Compound 3, half-maximal inhibitory concentration: 13000 nM
Estimate against measurement, compound 3: 3.7-fold (0.57 log units) below; the whole stated range lies below it.
By their numbers in this assay, from the lowest: compounds 1 and 2 (each within the scatter of the next); then compound 3.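

In this assay this position proves sensitive to which ring it carries: placing 2,3,6-trifluorophenyl there gives a 2.7-fold higher number from compound 2 to compound 3 (0.42 log units; beyond the scatter) and, measured against the 2-fluorophenyl ring, a 4.1-fold higher number from compound 1 to compound 3 (0.61 log units; beyond the scatter) as well. Both steps lie beyond the scatter, whereas the earlier exchange of 2-fluorophenyl for 3-methoxyphenyl gave no readable difference, so among the three rings shown only the 2,3,6-trifluorophenyl ring stands apart, with weaker inhibition. No measurement at hand speaks to the cause of this loss.

The compounds shown leave open whether the step follows from the number of fluorines or from their places on the ring, which a difluorophenyl ring could help to settle. They also leave open whether any aromatic ring is needed on that saturated chain carbon, as a pyridine ring or a plain alkyl chain there would show.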